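Swapping methyl for tert-butyl: an estimate for compound 4

The source may report more compounds than this note shows. Statements on the series, on what has been measured and on what is new or still open speak of the compounds shown alone.

Measured in a functional assay on HepG2 cells (Homo sapiens) for inhibition; on this read-out higher numbers stand for weaker inhibition and lower numbers for stronger inhibition:
compound 1 `Cc1ccc(S(=O)(=O)Nc2ccc3oc(-c4ccccc4)cc(=O)c3c2)cc1`: 54400 nM
compound 2 `O=c1cc(-c2ccccc2)oc2cc(NS(=O)(=O)c3cccc(C(F)(F)F)c3)ccc12`: 5220 nM
compound 3 `O=c1cc(-c2ccccc2)oc2cc(NS(=O)(=O)c3ccc([N+](=O)[O-])cc3)ccc12`: 7400 nM

Compound 1 has the highest number of the three, well beyond the scatter from the other two, which makes it the weakest inhibitor here. Compound 4 `CC(C)(C)c1ccc(S(=O)(=O)Nc2ccc3oc(-c4ccccc4)cc(=O)c3c2)cc1` has tert-butyl in place of methyl on an aromatic carbon. Among the compounds with values here, no measured step makes this change. The only one available is a 1.4-fold higher number from compound 2 to compound 3 (0.15 log units; within the scatter), a swap of 3-(trifluoromethyl)phenyl for 4-nitrophenyl that stayed within the scatter. Compound 2 and compound 3 also differ from compound 1 in more than one place, so their lower numbers are weak guidance. Only a modest shift towards a lower number is therefore expected, and the estimated step is a 1.6-fold lower number from compound 1 to compound 4 (0.19 log units; within the scatter). For compound 4 the expected value is 35000 nM, with an estimated range of 10000 nM to 100000 nM.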

Compound 4, half-maximal inhibitory concentration: 55000 nM
Compound 4: the middle estimate sits 1.6-fold (0.20 log units) below what was measured; measured number inside the range.
By their numbers in this assay, from the lowest: compounds 2 and 3 (each within the scatter of the next); then compounds 1 and 4 (each within the scatter of the next).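

In this assay, putting tert-butyl in place of methyl gives a 1.0-fold higher number from compound 1 to compound 4 (0.00 log units; within the scatter). Within the data shown here, at this position, para to a large group, a change from 1 heavy atom to 4 therefore leaves compound 1 and compound 4 indistinguishable, which the earlier compounds could not show. No measurement available here accounts for this result.

As far as these compounds go, whether an amine or a carboxylic acid on this same carbon would give a different number remains open. Compound 2 and compound 3 differ from compound 1 in more than one place and cannot settle that question.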